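The source may hold more compounds than are shown below. What is called first, only, known or untested is meant among the compounds shown, and "the series" means these compounds.

Measured compounds:
- Compound 1, `Cc1cc(F)ccc1NC(=O)CN1CCC(c2cccc[n+]2[O-])CC1`, gives 84% in a functional assay on HEK293 cells for agonist activity at D(4) dopamine receptor (Homo sapiens), read by FLIPR; on this read-out lower numbers stand for smaller maximal responses and higher numbers for larger maximal responses.
- Compound 2, `COc1cc(C(=O)NCN2CCC(c3cccc[n+]3[O-])CC2)ccc1Cl`, gives 54% in this assay.
- Compound 3, `CCOc1cccc(C(=O)NCN2CCC(c3cccc[n+]3[O-])CC2)c1`, gives 54% in this assay.

All three share a core built around a piperidine carrying a pyridine N-oxide, and differ in the amide part and the aryl group attached to it. Compound 1 stands at the top of these three numbers: the nearest, compound 2, lies lower, and compound 3 sits equally far below it. Both gaps are beyond the usual scatter of this measurement, so compound 1 gives the largest maximal response of the three. Within the data shown here, no step between any two of these measured compounds is recorded, since each pair differs in more than one place.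

Compound 4, `O=C(CN1CCC(c2cccc[n+]2[O-])CC1)Nc1ccccc1F`, is the untested member. Against compound 1 the change is 2-fluorophenyl in place of 4-fluoro-2-methylphenyl on an amide-type nitrogen. The aryl group on the amide-type nitrogen loses one carbon and keeps its single fluorine, while everything else in the molecule stays as in compound 1.

Among the measured compounds shown here, with no recorded step to lean on, only a cautious guess is possible. A small decrease in maximal response is expected in this assay, likely within or just beyond the scatter, since compound 1 holds 84% and the change is modest. Compound 4 is therefore expected to give 72%, with a plausible span from 52% to 92%, which means an expected step of a number 12 percentage points lower from compound 1 to compound 4 (beyond the scatter).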

Compound 4, largest response reached (reported as efficacy), in percent of the reference or control that the assay uses: 63%
The estimate for compound 4 lay 9 percentage points above the measured number; low and high end bracket the measured number.
By their numbers in this assay, from the lowest: compounds 2, 3 and 4 (each within the scatter of the next); then compound 1.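

Replacing 4-fluoro-2-methylphenyl with 2-fluorophenyl on the amide-type nitrogen provides the first one-place comparison among these compounds, and in this assay the result is a number 21 percentage points lower from compound 1 to compound 4 (beyond the scatter). Among these compounds, this shows that the maximal response depends on the aryl group at this position, which the earlier compounds could not show because each pair differed in more than one place. The names of the two groups show that the methyl group is lost and that the number marking the place of the fluorine also differs, and no supporting measurement explains the drop.

The compounds shown therefore leave open whether losing the methyl group, moving the fluorine, or both together account for the step. An unsubstituted phenyl on the same nitrogen, or a chlorine or methoxy group in place of the fluorine, would show how much of the response depends on what the aryl ring carries.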